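Triazole-linked series: trifluoromethyl for fluoro on the phenyl

The source may report more compounds than this note shows. Statements on the series, on what has been measured and on what is new or still open speak of the compounds shown alone.

Compound 1 `C=C1C[C@]23C[C@@]1(O)CC[C@H]2c1ccc(O)c(C)c1[C@@H]3Cn1cc(-c2ccc(C(F)(F)F)cc2)nn1`, compound 2 `C=C1C[C@]23C[C@@]1(O)CC[C@H]2c1ccc(O)c(C)c1[C@@H]3Cn1cc(-c2ccc(F)cc2)nn1` and compound 3 `C=C1C[C@]23C[C@@]1(O)CC[C@@H]2c1cccc(C)c1[C@@H]3Cn1cc(-c2ccc(F)cc2)nn1` have been tested; compound 4 `C=C1C[C@]23C[C@@]1(O)CC[C@@H]2c1cccc(C)c1[C@@H]3Cn1cc(-c2ccc(C(F)(F)F)cc2)nn1` has not. In a functional assay on MCF7 cells (Homo sapiens) for cytotoxicity, read by MTT assay, with a stated time of 4 days (a lower number here means a stronger inhibitor, a higher number a weaker inhibitor), compound 1 gives 12400 nM. For compound 2 the result in this assay is only a limit, > 20000 nM. For compound 3 the result in this assay is likewise only a limit, > 20000 nM. Two of the three measured values therefore sit at the limit of > 20000 nM in this assay, at which 2 of the 3 values shown sit, so the series as a whole is weak here.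

Going by the values given here, the one measured step, an at least 1.6-fold lower number from compound 2 to compound 1 (0.20 log units; that floor lies within the scatter), goes with the change (trifluoromethyl in place of fluoro on an aromatic carbon). The change from compound 3 to compound 4 is trifluoromethyl in place of fluoro on an aromatic carbon, the same kind of change at the same kind of place; the two "place" descriptions agree word for word, so it is the same change on a different core. How the core of compound 3 differs from that of compound 2 is not broken down here.

Since the measured step from compound 2 to compound 1 is only a floor that lies within the scatter, the change itself carries little information; compound 4 is expected to remain weak, and the step of an at least 1.3-fold lower number from compound 3 to compound 4 (0.12 log units; that floor lies within the scatter) is estimated to be of a comparable size. Compound 4 is expected to give about 15000 nM in this assay, within 6000 nM to 40000 nM, with a real chance that only a limit is reported.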

Compound 4, half-maximal inhibitory concentration: > 20000 nM
Compound 4: only a limit was reported; the forecaster's own chance of this, stated with the estimate: 55%; middle value at least 1.3-fold (0.12 log units) from the limit.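

In this assay compound 4 gives only a limit, > 20000 nM. Compound 3 likewise gives only a limit, > 20000 nM. Going by these compounds alone, no step can therefore be read between compound 3 and compound 4. The compounds shown leave open whether trifluoromethyl in place of fluoro shifts the value at all on the core of compound 3, since neither compound has a value beyond its limit.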